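Adding a (2-carboxyethyl)amino group to compound 2

A few compounds are considered here, and "the series" means these few. Any claim that something is new, unique, unknown or untested is made for them only; others in the source may bear on it.

Compound 1 `CC(C)(C)C1=CC(=O)C=C(NCCC(=O)O)C1=O` gives > 200000 nM
Compound 2 `CC1=CCC[C@H]2[C@](C)(CC3=CC(=O)C=CC3=O)[C@@H](C)CC[C@]12C` gives > 200000 nM

Both values come from an ADME assay on MRC5 cells (Homo sapiens) for cytotoxicity, read by MTT assay, with a stated time of 72 h (a higher number here means a weaker inhibitor, a lower number a stronger inhibitor), and neither is an exact number. Compound 1 gives > 200000 nM here, which is a limit of the assay. Compound 2 gives > 200000 nM here, which is also a limit. Compound 2 therefore stands at the limit of > 200000 nM in this assay, at which 2 of the 2 values shown sit, and has no exact value.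

Within the data shown here, compound 3 `CC1=CCC[C@H]2[C@](C)(CC3=CC(=O)C=C(NCCC(=O)O)C3=O)[C@@H](C)CC[C@]12C` has (2-carboxyethyl)amino in place of hydrogen on a double-bonded ring carbon of compound 2 (2-carboxyethyl)amino in place of hydrogen on a double-bonded ring carbon as its only change. Compound 1 carries the same group and gives > 200000 nM as its limit. Among the measured compounds shown here, no measured pair isolates this change, so the expectation in this assay is no shift beyond the usual scatter, in either direction. The expected change is a number no higher from compound 2 to compound 3 (the limit leaves the size open) and no larger. For compound 3 the estimated value is 200000 nM with an expected range of 80000 nM to 400000 nM in this test.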

Compound 3, half-maximal inhibitory concentration: 80800 nM
Compound 3: middle estimate off by 2.5-fold (0.39 log units), on the high side; the measured number falls inside the stated range.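

In this assay, (2-carboxyethyl)amino in place of hydrogen on a double-bonded ring carbon gives an at least 2.4-fold lower number from compound 2 to compound 3 (0.39 log units; beyond the scatter). A lower number here means stronger inhibition of the cells, so this position is not silent: the change moves the compound from a limit to an exact reading. That step is only a minimum, because compound 2 has no exact value: the limit of > 200000 nM in this assay, at which 2 of the 3 values shown sit.

The compounds shown leave open which part of the new group goes with the lower number, the nitrogen link or the carboxylic acid at its end. A simple amine, a methyl ester of the acid or a longer chain on the same ring carbon would help to separate these parts.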